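Methoxy in place of hydroxy on compound 2

A few compounds are considered here, and "the series" means these few. Any claim that something is new, unique, unknown or untested is made for them only; others in the source may bear on it.

Compound 2, `O=C(Nc1cccc(-n2cc(-c3ccncc3)c(-c3cc(O)cc(Cl)c3)n2)c1)Nc1ccc(Cl)c(Cl)c1`, gives the strongest read-out of the three measured compounds. In a functional assay on RXF 393 cells (Homo sapiens) for inhibition, read by sulforhodamine B assay, with a stated time of 48 h, tested at 10 uM (on this read-out lower numbers stand for a stronger effect and higher numbers for a weaker effect at the one concentration tested), compound 2 gives -70.3%. Its nearest neighbour is compound 1, `O=C(Nc1cccc(-n2cc(-c3ccncc3)c(-c3cc(O)cc(Cl)c3)n2)c1)Nc1ccc(Cl)c(C(F)(F)F)c1`, which in this assay gives -49.5%; the only difference between them is chloro in place of trifluoromethyl on an aromatic carbon, and that change is worth a number 20.8 percentage points lower from compound 1 to compound 2 (beyond the scatter). Furthest off is compound 3, `COc1cc(Cl)cc(-c2nn(-c3cccc(NC(=O)Nc4cc(C(F)(F)F)cc(C(F)(F)F)c4)c3)cc2-c2ccncc2)c1`, which in this assay gives -29.3%.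

Compound 4, `COc1cc(Cl)cc(-c2nn(-c3cccc(NC(=O)Nc4ccc(Cl)c(Cl)c4)c3)cc2-c2ccncc2)c1`, differs from compound 2 in one place: methyl in place of hydrogen on an oxygen on an aromatic ring. Within the data shown here, no measured pair isolates this change. Compound 3 does carry the methoxy and gives the weakest number, but it also differs from compound 2 in the other aryl of the urea, so its value cannot be read as the effect of methylation alone.

Among the measured compounds shown here, with no step of this kind measured, the expectation for compound 4 is a move towards a weaker read-out, of a size that stays uncertain; the expected step is a number 15.3 percentage points higher from compound 2 to compound 4 (beyond the scatter). Compound 4 is therefore estimated to give -55% in this assay, with a range from -80% to -25%.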

Compound 4, a percentage reported as activity, at one concentration (the size of the read-out at that concentration, not a potency): 4.46%
Beside the measured number, compound 4's estimate is 59.5 percentage points below it; measured number outside the range, above it.
By their numbers in this assay, from the lowest: compound 2; then compound 1; then compound 3; then compound 4.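

Capping the oxygen on the aromatic ring with a single methyl gives a number 74.8 percentage points higher from compound 2 to compound 4 (beyond the scatter), so in this assay this position proves far more sensitive than anything the earlier compounds could show. Among these compounds, the only step measured before, on the other aryl of the urea, was modest by comparison: a number 20.8 percentage points lower from compound 1 to compound 2 (beyond the scatter). Among the compounds that differ in one place, the change from 3-chloro-5-hydroxyphenyl to 3-chloro-5-methoxyphenyl is the one that removes the effect at the one concentration tested, and nothing available explains why this small change has so large a result.

The compounds shown leave open whether the loss comes from losing the hydrogen on the oxygen or from adding the methyl, as only hydroxy and methoxy appear on this carbon, and an amine or an ethoxy there would help to separate the two. They also leave open whether the same step would hold with the trifluoromethyl-bearing urea aryl of compound 1, whose methoxy counterpart is not among the compounds shown here.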